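Bromo to chloro in two related cores

The source may report more compounds than this note shows. Statements on the series, on what has been measured and on what is new or still open speak of the compounds shown alone.

Compound 1 `COC(=O)[C@@]1(C)CCC=C2[C@@H]1CC[C@@H](C)[C@]2(C)Cc1c[nH]c2c(Br)cccc12` in a functional assay on SW1573 cells (Homo sapiens) for inhibition, read by sulforhodamine B assay, with a stated time of 48 h (a higher number here means a weaker inhibitor of growth, a lower number a stronger inhibitor of growth), gives 14000 nM.
Compound 2 `COC(=O)[C@@]1(C)CCC=C2[C@@H]1CC[C@@H](C)[C@]2(C)Cc1c[nH]c2c(Cl)cccc12` in this assay gives 14000 nM.
Compound 3 `COC(=O)[C@@]1(C)CC[C@@H]2C3=C1CC[C@@H](C)[C@]3(C)C[C@@H]1c3cccc(Br)c3N[C@H]21` in this assay gives 44000 nM.

Compounds 1 and 2 share a core and differ only in chloro in place of bromo on an aromatic carbon. The step of no change at the digits printed from compound 1 to compound 2 (within the scatter) shows that this halogen swap leaves the read-out unchanged on the core of compound 1.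

Compound 3 is built from the same atoms as compound 1 joined differently, and the difference between the two cores is not broken down here. Compound 3 gives the highest number of the three, beyond the scatter from compound 1 and from compound 2.

Compound 4 `COC(=O)[C@@]1(C)CC[C@@H]2C3=C1CC[C@@H](C)[C@]3(C)C[C@@H]1c3cccc(Cl)c3N[C@H]21` differs from compound 3 by chloro in place of bromo on an aromatic carbon. This is the same kind of change as that from compound 1 to compound 2, but the ring that carries the halogen is here part of a fused or bridged system of five rings rather than two. Because the step of no change at the digits printed from compound 1 to compound 2 (within the scatter) was flat, compound 4 is expected to sit close to compound 3 in this assay. For compound 4 the expected step is no change at the digits printed from compound 3 to compound 4 (within the scatter). Compound 4 is therefore estimated at 44000 nM, with a range from 22000 nM to 88000 nM.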

Compound 4, concentration for 50% growth inhibition: 49000 nM
Compound 4: the middle estimate sits 1.1-fold (0.05 log units) below what was measured, within the range that was stated.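

In this assay the step of a 1.1-fold higher number from compound 3 to compound 4 (0.05 log units; within the scatter) comes with chloro in place of bromo on an aromatic carbon, so the swap leaves the read-out flat on the core of compound 3, as it did on the core of compound 1. Set side by side, the two steps do not differ: the same change on two cores in this assay, no change at the digits printed (within the scatter) from compound 1 to compound 2 and a 1.1-fold higher number (0.05 log units; within the scatter) from compound 3 to compound 4, 1.1-fold (0.05 log units) apart, within the scatter of two such steps. Within the data shown here, this shows that, on these two cores, the halogen swap carries from one core to the other with no difference that the measurements can resolve, but it rests on only two pairs and one kind of change, and it does not show that any other change would carry over in the same way.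

Only the two halogens appear at this place, so the compounds shown leave open what a fluoro, a methoxy or an amine on the same aromatic carbon would do on either core. They also leave open whether a carboxylic acid or an amide in place of the methyl ester would shift the read-out, and whether that change would carry across both cores.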